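The compounds below may be only part of what the source reports. "The series", "measured", "known", "first", "only" and "open" are said of these compounds alone.

Of the compounds shown here, three have been measured in a functional assay on A-375 cells (Homo sapiens) for cytotoxicity, read by MTT assay, with a stated time of 48 h; a lower number here means a stronger inhibitor, a higher number a weaker inhibitor. Compound 2 `CC1(C)S[C@@H]2/C(=C\C(=O)c3ccc(F)cc3)C(=O)N2[C@H]1C(=O)OC(c1ccccc1)c1ccccc1` gives 17800 nM, the lowest of the three numbers. Compound 1 `CC1(C)[C@H](C(=O)OC(c2ccccc2)c2ccccc2)N2C(=O)/C(=C/C(=O)c3ccc([N+](=O)[O-])cc3)[C@H]2[S+]1[O-]` differs from compound 2 in several places. In this assay compound 1 gives 48200 nM. Compound 3 `CC1(C)[C@H](C(=O)OC(c2ccccc2)c2ccccc2)N2C(=O)/C(=C/C(=O)c3ccc([N+](=O)[O-])cc3)[C@H]2S1(=O)=O` gives 76700 nM in this assay, the highest of the three; both gaps to compound 2 lie beyond the scatter. Compound 4 `CC1(C)S[C@@H]2/C(=C\C(=O)c3ccco3)C(=O)N2[C@H]1C(=O)OC(c1ccccc1)c1ccccc1` is not yet measured. It differs from compound 2 in one place: furan-2-yl in place of 4-fluorophenyl on a carbonyl carbon. Among the compounds with values here, no measured pair isolates this change, so the expectation rests on compound 2 alone. The expected step is a 1.6-fold higher number from compound 2 to compound 4 (0.20 log units; within the scatter), a small rise in the number, near the edge of the scatter. Compound 4 is expected at 28000 nM in this assay, within 9000 nM to 85000 nM.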

Compound 4, half-maximal inhibitory concentration: 26000 nM
Compound 4: the middle estimate sits 1.1-fold (0.03 log units) above what was measured; low and high end bracket the measured number.
By their numbers in this assay, from the lowest: compounds 2, 4, 1 and 3 (each within the scatter of the next, the first and the last beyond it).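

At this carbonyl carbon, furan-2-yl in place of 4-fluorophenyl gives in this assay a 1.5-fold higher number from compound 2 to compound 4 (0.16 log units; within the scatter) and so does not separate the two groups. Within the data shown here, this is the first step that isolates a single difference, and it shows that a five-membered aromatic ring with 1 hetero atom can stand here in place of a six-membered aromatic ring of carbon only without a step beyond the scatter. No measured evidence bears on the reason for this result. Still open, on these data alone, is how an amine or a longer chain on this carbonyl carbon would read.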